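Two-methylphenyl to three-bromophenyl on a fused spiro-oxindole scaffold

This account rests on a few compounds, and the source may have more. Where it says the series, first, only, none or still open, it means among the compounds named here.

Two close relatives have been tested in a functional assay on A549 cells (Homo sapiens) for antiproliferative activity, read by MTT assay, with a stated time of 48 h; a lower number here means a stronger inhibitor, a higher number a weaker inhibitor. Compound 1 `N#CC1=C(N)Oc2c(c3nc4ccccc4nc3c3ccccc23)C12C(=O)N(Cc1cnnn1-c1cccc(Cl)c1)c1ccccc12` gives 32600 nM, and compound 2 `Cc1ccccc1-n1nncc1CN1C(=O)C2(C(C#N)=C(N)Oc3c(N)cc4nc5ccccc5nc4c32)c2ccccc21` gives 31700 nM; the two numbers lie within the usual scatter of each other, so neither can be said to stand apart from the other. Compound 3 `N#CC1=C(N)Oc2c(N)cc3nc4ccccc4nc3c2C12C(=O)N(Cc1cnnn1-c1cccc(Br)c1)c1ccccc12` has not yet been measured; it differs from compound 2 by 3-bromophenyl in place of 2-methylphenyl on an aromatic nitrogen. For the measured compounds named here, no measured pair in this set differs by a single change, so nothing directly shows what such a swap does. Since compound 1 and compound 2 already sit so close together despite their differences, the expectation for compound 3 is a step from compound 2 of a 1.1-fold lower number from compound 2 to compound 3 (0.02 log units; within the scatter), not beyond the scatter in either direction. Compound 3 is therefore estimated at 30000 nM in this assay, with a range from 14000 nM to 65000 nM.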

Compound 3, half-maximal inhibitory concentration: 18900 nM
Compound 3: the middle estimate sits 1.6-fold (0.20 log units) above what was measured, within the range that was stated.
By their numbers in this assay, from the lowest: compounds 3, 2 and 1 (each within the scatter of the next).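

On the aromatic nitrogen of the five-membered ring with 3 nitrogen, 3-bromophenyl in place of 2-methylphenyl gives, in this assay, a 1.7-fold lower number from compound 2 to compound 3 (0.22 log units; within the scatter). For the compounds shown here, this is the first comparison in the set that isolates a single place, and it shows that one substituted phenyl can be exchanged for the other at this position without a step beyond the scatter. No independent measurement is available to account for the result.

The exchange alters both the substituent and its place on the phenyl ring, so this pair cannot separate the two. From the compounds shown here alone, whether an amine or a carboxylic acid on that phenyl ring, or a longer chain in place of the ring, would produce a step beyond the scatter remains open.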